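Sulfonamide aryl swap and expected oral exposure

A few compounds are considered here, and "the series" means these few. Any claim that something is new, unique, unknown or untested is made for them only; others in the source may bear on it.

For the measured compounds named here, compound 2 `O=C(O)c1ccccc1NS(=O)(=O)c1ccc2nc(-c3ccccc3)c(-c3ccccc3)nc2c1` gives 83.6% in an ADME assay on the whole organism for pharmacokinetics, with Homo sapiens as the target (a higher number here means that a larger share of the oral dose reaches the circulation, a lower number that a smaller share of the oral dose reaches the circulation), the lower of the two numbers known, while compound 1 `COc1ccccc1NS(=O)(=O)c1ccc2nc(-c3ccccc3)c(-c3ccccc3)nc2c1` gives 100%. Going by the values given here, the single measured step, a number 16.4 percentage points lower from compound 1 to compound 2 (beyond the scatter), is the only one that bears here. Compound 3 `O=S(=O)(Nc1ccc(Cl)cc1)c1ccc2nc(-c3ccccc3)c(-c3ccccc3)nc2c1` differs from compound 2 by 4-chlorophenyl in place of 2-carboxyphenyl on a sulfonamide nitrogen, so the carboxy that accompanied the drop from compound 1 leaves. Compound 3 is therefore expected to move back toward compound 1, by a number 6.4 percentage points higher from compound 2 to compound 3 (within the scatter). The estimate for compound 3 is 90%, between 70% and 100%.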

Compound 3, oral bioavailability: 100%
The estimate for compound 3 lay 10 percentage points below the measured number; the measured number falls inside the stated range.
By their numbers in this assay, from the lowest: compound 2; then compounds 1 and 3 (each within the scatter of the next).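

In this assay the sulfonamide nitrogen carries either 2-methoxyphenyl or 4-chlorophenyl with no change at the digits printed from compound 1 to compound 3 (within the scatter) and, by contrast, 4-chlorophenyl in place of 2-carboxyphenyl gives a number 16.4 percentage points higher from compound 2 to compound 3 (beyond the scatter) here. Among these three compounds, only compound 2, with its 2-carboxyphenyl, stands apart. No measurement given here explains this difference.

Because this change replaces the whole aryl group, the compounds shown cannot separate the loss of the carboxy from the entry of the chlorine. From the compounds shown here alone, how an amine or a methyl ester on that aryl ring would read remains open.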